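Cyclohexyl in Place of a Halogenated Benzyl: Permeability Outlook

The compounds below may be only part of what the source reports. "The series", "measured", "known", "first", "only" and "open" are said of these compounds alone.

Of the compounds shown here, three built on one shared core have so far been measured in an ADME assay for permeability, using PAMPA, with a stated time of 30 min, at pH 7.4; on this read-out higher numbers stand for higher permeability and lower numbers for lower permeability. Compound 1 `COc1cccc(Oc2ccc3c(NCCCNCc4cccc(OC)c4O)ccnc3c2)c1` gives 317 10^-6 cm/s. Compound 2 `COc1cccc(CNCCCNc2ccnc3cc(-c4ccccc4)ccc23)c1O` gives 237 10^-6 cm/s; the step of a 1.3-fold lower number from compound 1 to compound 2 (0.13 log units; within the scatter) stays within the scatter, so these two cannot be ranked against each other. Compound 3 `COc1cccc(CNCCCNc2ccnc3cc(Cc4ccc(F)cc4Cl)ccc23)c1O` gives 23 10^-6 cm/s, the lowest of the three numbers: the step of a 14-fold lower number from compound 1 to compound 3 (1.14 log units; beyond the scatter) and the step of a 10-fold lower number from compound 2 to compound 3 (1.01 log units; beyond the scatter) are both large and beyond the scatter, and the other two compounds sit well above it.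

The next compound, compound 4 `COc1cccc(CNCCCNc2ccnc3cc(C4CCCCC4)ccc23)c1O`, differs from compound 3 in one place: cyclohexyl in place of 2-chloro-4-fluorobenzyl on an aromatic carbon. The two measured steps that end at compound 3 bear on this change. Each put a different group onto the same aromatic carbon and each showed a large drop, a 14-fold lower number from compound 1 to compound 3 (1.14 log units; beyond the scatter) and a 10-fold lower number from compound 2 to compound 3 (1.01 log units; beyond the scatter). Compound 2 carries phenyl at that place, and the incoming cyclohexyl is likewise a single six-membered ring of carbon only. The step of a 6.5-fold higher number from compound 3 to compound 4 (0.81 log units; beyond the scatter) is therefore expected to be a rise beyond the scatter, carrying the number back toward compound 2. The estimate for compound 4 in this assay is 150 10^-6 cm/s, with a range from 40 10^-6 cm/s to 400 10^-6 cm/s.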

Compound 4, apparent permeability: 23 10^-6 cm/s
Estimate against measurement, compound 4: 6.5-fold (0.81 log units) above; measured number outside the range, below it.
By their numbers in this assay, from the lowest: compounds 3 and 4 (each within the scatter of the next); then compounds 2 and 1 (each within the scatter of the next).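

Replacing phenyl with cyclohexyl keeps a single six-membered ring of carbon only but turns it from aromatic to non-aromatic, and in this assay this one change gives a 10-fold lower number from compound 2 to compound 4 (1.01 log units; beyond the scatter) and the replacement of 3-methoxyphenoxy gives a 14-fold lower number from compound 1 to compound 4 (1.14 log units; beyond the scatter) at this position. Sharing ring size and ring atoms with phenyl therefore did not keep the number high, and very different groups can end up level: the step shows no change at the digits printed from compound 3 to compound 4 (within the scatter) even though cyclohexyl has 6 heavy atoms and no halogen, while 2-chloro-4-fluorobenzyl has 9 heavy atoms, an aromatic ring, fluorine and chlorine. Nothing measured here gives a reason for either result.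

Going by these compounds, what separates compound 1 and compound 2 from compound 3 and compound 4 remains open: an aromatic ring alone does not, as compound 3 carries one and its number is low. A pyridyl ring, a piperidine ring or a short chain such as ethyl on this aromatic carbon could show whether the number lies nearer compound 2 or compound 4.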